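Working notes: the step from compound 3 to compound 4

The source may hold more compounds than are shown below. What is called first, only, known or untested is meant among the compounds shown, and "the series" means these compounds.

Values so far in an ADME assay on microsomes from liver (Homo sapiens) for metabolic stability, with a stated time of 10 min (a lower number here means that less of the compound is left, a higher number that more of the compound is left), for the series:
- compound 1 `CCC[C@]1(C(=O)N2CC[C@](c3ccc(C(F)(C(F)(F)F)C(F)(F)F)cc3)(S(=O)(=O)c3ccc(F)cc3)C2)CC[C@H](C(=O)O)CC1` gives "not determined" (no result reported)
- compound 2 `CO[C@]1(C(=O)N2CC[C@](c3ccc(C(F)(C(F)(F)F)C(F)(F)F)cc3)(S(=O)(=O)c3ccc(F)cc3)C2)CC[C@H](C(=O)O)CC1` gives 82%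
- compound 3 `O=C(O)C12CCC(C(=O)N3CC[C@](c4ccc(C(F)(C(F)(F)F)C(F)(F)F)cc4)(S(=O)(=O)c4ccc(F)cc4)C3)(CC1)CC2` gives 100%

Compound 3 holds the highest of the two numbers in this assay (100%), and compound 1 adds no number. Compound 4 `O=C([C@H]1CC[C@H](c2nnn[nH]2)CC1)N1CC[C@](c2ccc(C(F)(C(F)(F)F)C(F)(F)F)cc2)(S(=O)(=O)c2ccc(F)cc2)C1` is not yet measured. It carries a 4-(1H-tetrazol-5-yl)cyclohexyl on the carbonyl carbon (a group of 11 heavy atoms (7 carbon, 4 nitrogen; one five-membered aromatic ring with 4 hetero atoms, one six-membered non-aromatic ring of carbon only) in place of a group of 11 heavy atoms (9 carbon, 2 oxygen; 2 six-membered non-aromatic rings of carbon only), on a carbonyl carbon).

Going by the values given here, the only measured step at this place is a number 18 percentage points higher from compound 2 to compound 3 (beyond the scatter), and neither of its compounds carries the entering group. That step therefore bears only loosely on the change and gives its likely size, not its direction. Compound 3 leaves no measured room above it, so a loss of similar or smaller size is expected. The estimated change is a number 10 percentage points lower from compound 3 to compound 4 (within the scatter), and it may prove to lie within the scatter. Compound 4 is expected at 90% (estimated range 72% to 100%).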

Compound 4, percent of the compound remaining: 100%
For compound 4 the middle estimate is 10 percentage points below the measured one, within the range that was stated.
By their numbers in this assay, from the lowest: compound 2; then compounds 3 and 4 (each within the scatter of the next).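

In this assay, the place on a carbonyl carbon whose other neighbour is the amide-type nitrogen in a ring accepts 4-(1H-tetrazol-5-yl)cyclohexyl with no change at the digits printed from compound 3 to compound 4 (within the scatter), so the two groups cannot be told apart in this read-out. The same group gives a number 18 percentage points higher from compound 2 to compound 4 (beyond the scatter), matching a number 18 percentage points higher from compound 2 to compound 3 (beyond the scatter) in size, so the rise over 4-carboxy-1-methoxycyclohexyl does not depend on the two carbon-only rings of compound 3. No measurement at hand accounts for either step.

The compounds shown leave open whether the tetrazole itself matters, as a cyclohexyl carrying an amine or a primary carboxamide in its place could read differently in this assay. They also leave open whether the methoxy group or the carboxylic acid of compound 2 sets its lower number.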